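Replacing the dimethylaminoethyl arm with phenyl

A few compounds are considered here, and "the series" means these few. Any claim that something is new, unique, unknown or untested is made for them only; others in the source may bear on it.

Compound 1 `CN1CCN(c2ccc(Nc3ncc4c(=O)c(-c5c(Cl)cccc5Cl)cn(C)c4n3)cc2)CC1` gives 520 nM in a functional assay on NCI-H1299 cells (Homo sapiens) for antiproliferative activity, with a stated time of 72 h; a lower number here means that less compound is needed, a higher number that more compound is needed for the effect. Compound 2 `CN1CCN(c2ccc(Nc3ncc4c(=O)c(-c5c(Cl)cccc5Cl)cn(C5COC5)c4n3)cc2)CC1` gives 1720 nM, and compound 3 `CN(C)CCn1cc(-c2c(Cl)cccc2Cl)c(=O)c2cnc(Nc3ccc(N4CCN(C)CC4)cc3)nc21` gives 7650 nM; compound 3 therefore stands at the highest number of the three, with compound 2 the nearest and compound 1 the furthest below it. The step to compound 4 `CN1CCN(c2ccc(Nc3ncc4c(=O)c(-c5c(Cl)cccc5Cl)cn(-c5ccccc5)c4n3)cc2)CC1` is phenyl in place of 2-(dimethylamino)ethyl on an aromatic nitrogen. Among the measured compounds shown here, no measured pair carries a phenyl at this nitrogen, so the bearing steps are those that remove the 2-(dimethylamino)ethyl group: a 15-fold higher number from compound 1 to compound 3 (1.17 log units; beyond the scatter) and a 4.4-fold higher number from compound 2 to compound 3 (0.65 log units; beyond the scatter), both beyond the scatter and both showing lower numbers for the two other groups on that nitrogen. Both substituents measured in place of this arm gave lower numbers, so compound 4 is expected to move downward, probably by a modest amount, as a 5.1-fold lower number from compound 3 to compound 4 (0.71 log units; beyond the scatter). On these data alone, since the phenyl is untested here, the range is kept wide. Compound 4 is estimated at 1500 nM, between 400 nM and 6000 nM.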

Compound 4, half-maximal effective concentration: 500 nM
Beside the measured number, compound 4's estimate is 3.0-fold (0.48 log units) above it; the measured number falls inside the stated range.
By their numbers in this assay, from the lowest: compounds 4 and 1 (each within the scatter of the next); then compound 2; then compound 3.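

In this assay, a six-membered aromatic ring of carbon on this nitrogen sits at the low end of the series: there is a 15-fold lower number from compound 3 to compound 4 (1.18 log units; beyond the scatter) and a 3.4-fold lower number from compound 2 to compound 4 (0.54 log units; beyond the scatter), while a 1.0-fold lower number from compound 1 to compound 4 (0.02 log units; within the scatter) leaves phenyl level with methyl. The earlier compounds shown here could be read as the number rising as the group grew from methyl through oxetan-3-yl to 2-(dimethylamino)ethyl, but compound 4 goes against that reading, since its phenyl has 6 heavy atoms against the 5 of the arm it replaces. Nothing in the information available explains why these groups differ.

On these data alone, whether the high number of compound 3 belongs to its amine or to its chain remains open, and a 2-methoxyethyl or a propyl group on this nitrogen would separate the two. As far as these compounds go, it is also open whether a pyridine ring, a benzyl group or a phenyl carrying fluorine would stay as low as phenyl.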